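Adding a sulfonyl group to compound 2

A few compounds are considered here, and "the series" means these few. Any claim that something is new, unique, unknown or untested is made for them only; others in the source may bear on it.

Compound 2 `O=C1/C(=C/c2ccncc2)CNC/C1=C\c1ccccc1F` gives 14700 nM in an ADME assay on L02 cells (Homo sapiens) for cytotoxicity, read by MTT assay, with a stated time of 24 h (on this read-out lower numbers stand for stronger inhibition and higher numbers for weaker inhibition), and stands level with compound 1 `Cc1ccc(S(=O)(=O)N2C/C(=C\c3cccnc3)C(=O)/C(=C/c3ccccc3F)C2)cc1` at 14900 nM within the usual scatter. Going by the values given here, compound 3 `Cc1ccc(S(=O)(=O)N2C/C(=C\c3ccncc3)C(=O)/C(=C/c3ccccc3F)C2)cc1` has (4-methylphenyl)sulfonyl in place of hydrogen on an amine nitrogen in a ring of compound 2 (4-methylphenyl)sulfonyl in place of hydrogen on an amine nitrogen in a ring as its one change. Among the compounds with values here, no measured pair shows this change alone. With compound 2 at 14700 nM and compound 1 at 14900 nM in this assay there is no sign of a large shift, so no step beyond the scatter is expected. The estimated 1.1-fold lower number from compound 2 to compound 3 (0.05 log units; within the scatter) is expected to stay small. Compound 3 is expected at 13000 nM with a likely range from 6000 nM to 28000 nM when measured.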

Compound 3, half-maximal inhibitory concentration: > 20000 nM
Compound 3 was reported as a limit; the forecaster's own chance of this, stated with the estimate: 10%; middle value at least 1.5-fold (0.18 log units) away from the limit.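

In this assay, compound 3 is reported only as a limit, > 20000 nM, not as an exact number. Putting (4-methylphenyl)sulfonyl on the ring nitrogen gives an at least 1.3-fold higher number from compound 2 to compound 3 (0.13 log units; that floor lies within the scatter), and pyridin-4-yl in place of pyridin-3-yl gives an at least 1.3-fold higher number from compound 1 to compound 3 (0.12 log units; that floor lies within the scatter), so neither change can yet be told from the scatter. The true size of both steps remains hidden: the limit of > 20000 nM in this assay, at which 1 of the 3 values shown sits.

Going by these compounds, whether a smaller group on this ring nitrogen, such as methyl or acetyl, would shift the number remains open.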